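The compounds below may be only part of what the source reports. "The series", "measured", "known", "first", "only" and "open" are said of these compounds alone.

Compounds measured so far:

Compound 1, `CC1CCCCN1C(=S)SCc1ccc(C(=O)Nc2ccccc2N)cc1`: 45.5%
Compound 2, `Nc1ccccc1NC(=O)c1ccc(CSC(=S)N2CCN(c3ccncc3)CC2)cc1`: 77%
Compound 3, `Nc1ccccc1NC(=O)c1ccc(CSC(=S)N(Cc2ccccc2)Cc2ccccc2)cc1`: 1%

All three share the same core and were tested in a functional assay on HeLa cells (Homo sapiens) for antiproliferative activity, read by CCK-8 assay, with a stated time of 72 h, tested at 2 uM; a higher number here means a stronger effect of the compound at the concentration tested, a lower number a weaker effect. Compound 2 gives 77%, the highest of the three numbers. The nearest is compound 1, whose value of 45.5% lies beyond the scatter of repeated measurements below it, and the furthest is compound 3, whose 1% lies far beyond the scatter below it. Only the two ring-bearing amines of compound 1 and compound 2 show a sizable effect in this assay; the acyclic pair of benzyl groups in compound 3 shows almost none.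

Compound 4, `Nc1ccccc1NC(=O)c1ccc(CSC(=S)N2CCN(c3ccccc3)CC2)cc1`, has not yet been measured. It differs from compound 2 in one place: phenyl in place of pyridin-4-yl on an amine nitrogen in a ring. Going by the values given here, no step between measured compounds tells how such a change behaves in this assay; the counted difference is one hydrogen-bond acceptor fewer on the six-membered aromatic ring that sits on the ring nitrogen. Among the compounds with values here, because compound 2 gives 77%, and nothing among the measured compounds points to a gain, a modest drop is expected, of a size that may not clearly exceed the scatter. Compound 4 is therefore estimated at 62%, within a range from 35% to 85%. The expected step in this assay is a number 15 percentage points lower from compound 2 to compound 4 (beyond the scatter).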

Compound 4, a percentage reported as inhibition, at one concentration (the size of the read-out at that concentration, not a potency): 62.2%
Beside the measured number, compound 4's estimate is 0.2 percentage points below it, and the stated range covers the measured number.
By their numbers in this assay, from the lowest: compound 3; then compound 1; then compound 4; then compound 2.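

In this assay, going by these compounds alone, this is the first comparison of two compounds that differ in one place only, and the step is a number 14.8 percentage points lower from compound 2 to compound 4 (beyond the scatter), with phenyl replacing pyridin-4-yl on the ring nitrogen. The pyridin-4-yl group carries a hydrogen-bond acceptor that phenyl lacks, yet compound 4 still gives 62.2% at the single concentration tested, so this position keeps a sizable read-out with a ring of carbon only, although the value drops. Nothing measured in the data accounts for the size of this drop.

Open, as far as these compounds go, is whether the place of the nitrogen within the aromatic ring matters, as pyridin-3-yl or pyridin-2-yl on the same ring nitrogen would show, and whether a second ring nitrogen, as in pyrimidin-5-yl, would change the read-out. From the compounds shown here alone, it is equally open whether an aromatic ring is needed at this position at all, which a methyl or an acetyl group there would test in this assay at the same concentration.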